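The compounds below may be only part of what the source reports. "The series", "measured", "known", "first", "only" and "open" are said of these compounds alone.

Measured so far in a functional assay on a cell-free system (Platelet, plasma, Homo sapiens) for inhibition, read by turbidimetry, with a stated time of 3 min; on this read-out lower numbers stand for stronger inhibition and higher numbers for weaker inhibition:
- compound 1 `COc1ccc(-n2nc(C(=O)Nc3ccc(Cl)cc3)cc2-c2ccc(Cl)cc2)nn1`: 610 nM
- compound 2 `COc1ccc(-n2nc(CCC(=O)N3CCOCC3)cc2-c2ccc(Cl)cc2)nn1`: 1080 nM

Going by the values given here, compound 2, at 1080 nM, lies within the scatter of compound 1, the only other measured compound, at 610 nM. The next compound, compound 3 `COc1ccc(-n2nc(C(=O)N3CCCC3)cc2-c2ccc(Cl)cc2)nn1`, keeps the shared core and carries (pyrrolidin-1-yl)carbonyl in place of 2-((morpholin-4-yl)carbonyl)ethyl on an aromatic carbon.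

Among the compounds with values here, one measured step bears on this change, as it replaced a group at the same carbon: a 1.8-fold higher number from compound 1 to compound 2 (0.25 log units; within the scatter). That single step stayed within the scatter, although the groups exchanged were quite different. It is weak evidence, but it gives no reason to expect a large shift in this assay. The expected change is a 1.4-fold lower number from compound 2 to compound 3 (0.13 log units; within the scatter), which would also stay within the scatter. Compound 3 is estimated at 800 nM, with an expected range from 280 nM to 2300 nM.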

Compound 3, half-maximal inhibitory concentration: 15 nM
Beside the measured number, compound 3's estimate is 53-fold (1.73 log units) above it; measured number below the stated range.
By their numbers in this assay, from the lowest: compound 3; then compounds 1 and 2 (each within the scatter of the next).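

This result shows that the position on the aromatic carbon is far more sensitive in this assay than the earlier step, which stayed within the scatter, had suggested (a 72-fold lower number from compound 2 to compound 3 (1.86 log units; beyond the scatter)). With the carbonyl kept on the ring, exchanging only the (4-chlorophenyl)amino for pyrrolidin-1-yl also gives a large change (a 41-fold lower number from compound 1 to compound 3 (1.61 log units; beyond the scatter)), so the group on the carbonyl carbon alone can move this number strongly. The data offer no measurement that explains either large step.

The step from compound 2 to compound 3 exchanges both the ring and the ethyl chain, so their separate shares remain unresolved. From the compounds shown here alone, it also remains open whether a piperidin-1-yl, a morpholin-4-yl or a dimethylamino group on the same carbonyl would give a number as low as that of compound 3.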